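Three inactive amides and a fourth to predict

The source may report more compounds than this note shows. Statements on the series, on what has been measured and on what is new or still open speak of the compounds shown alone.

Compound 1 has the structure `COc1ccc2nc(C)cc(OCC(=O)NCc3cc(C)cc(C)c3)c2c1` and in a toxicity assay on HepG2 cells (Homo sapiens) for inhibition, read by CellTiter-Glo, with a stated time of 48 h (on this read-out lower numbers stand for stronger inhibition and higher numbers for weaker inhibition), compound 1 reaches only the limit > 100000 nM.
Compound 2 has the structure `COc1ccc(NC(=O)COc2cc(C)nc3ccc(OC)cc23)cc1` and in this assay compound 2 reaches only the limit > 100000 nM.
Compound 3 has the structure `COc1ccc2nc(C)cc(OCC(=O)Nc3ccccn3)c2c1` and in this assay compound 3 reaches only the limit > 100000 nM.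

Compound 3 therefore stands at the limit of this assay, and so do the two compounds beside it, as the limit of > 100000 nM in this assay, at which 3 of the 3 values shown sit, records. The step that the two limits leave unreadable from compound 1 to compound 3 cannot be read, nor can a step that the two limits leave unreadable from compound 2 to compound 3 or a step that the two limits leave unreadable from compound 1 to compound 2, since each pair sits at the same limit. Compound 4 has the structure `COc1ccc2nc(C)cc(OCC(=O)Nc3c(C)cncc3C)c2c1`; the change from compound 3 is 3,5-dimethylpyridin-4-yl in place of pyridin-2-yl on an amide-type nitrogen. For the measured compounds named here, none of the measured steps gives a readable size to carry over, so no movement beyond the scatter is expected in this assay. Compound 4 is accordingly expected to remain at or near the limit, with an estimate of 100000 nM and a range from 40000 nM to 300000 nM. The step this estimate implies is a number no higher from compound 3 to compound 4 (the limit leaves the size open), expected to be essentially none.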

Compound 4, half-maximal inhibitory concentration: 12600 nM
The estimate for compound 4 lay 7.9-fold (0.90 log units) above the measured number; the measured number lies below the stated range.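

On the amide-type nitrogen, 3,5-dimethylpyridin-4-yl is the only group shown that comes off the limit in this assay, with an at least 7.9-fold lower number from compound 3 to compound 4 (0.89 log units; beyond the scatter), and the same group gives an at least 7.9-fold lower number from compound 2 to compound 4 (0.89 log units; beyond the scatter) and an at least 7.9-fold lower number from compound 1 to compound 4 (0.89 log units; beyond the scatter). The pyridin-2-yl, 4-methoxyphenyl and 3,5-dimethylbenzyl groups could not show this, and the steps among their compounds cannot be read. Each new step is a minimum rather than a full size, because each starting compound sits at a limit: the limit of > 100000 nM in this assay, at which 3 of the 4 values shown sit.

The compounds shown leave open whether the two methyl groups or the pyridin-4-yl attachment carries the step, which a plain pyridin-4-yl on the same nitrogen would help to separate. They also leave open whether a 3,5-dimethylphenyl group, which lacks the ring nitrogen, would behave like 3,5-dimethylpyridin-4-yl.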